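This account rests on a few compounds, and the source may have more. Where it says the series, first, only, none or still open, it means among the compounds named here.

Compound 1 `C/C(=N\OCC(=O)O)c1ccc(Br)cc1`: 27 mg/kg
Compound 2 `COC(=O)CO/N=C(\C)c1ccc(Br)cc1`: 14 mg/kg
Compound 3 `C/C(=N\OCC(N)=O)c1ccc(Cl)cc1`: 24 mg/kg

In a functional assay on the whole organism for inhibition, with Rattus norvegicus as the target, read by paw edema, with stated times of 1 h and 3 h (on this read-out lower numbers stand for an effect already at smaller amounts and higher numbers for an effect only at larger amounts of compound), compound 3 lies within the scatter of both compound 1 and compound 2. Compound 4 `C/C(=N\OCC(N)=O)c1ccc(Br)cc1` has bromo in place of chloro on an aromatic carbon. Among the measured compounds shown here, no measured step makes this exchange directly. For the measured compounds named here, the only measured step, a 1.9-fold lower number from compound 1 to compound 2 (0.29 log units; within the scatter), concerns another part of the molecule and stays within the scatter. Compound 1 already carries bromo and gives 27 mg/kg, so it offers only indirect support for expecting no step beyond the scatter in this assay. The expected change is a 1.1-fold lower number from compound 3 to compound 4 (0.04 log units; within the scatter), which would remain within the scatter. Compound 4 is estimated at 22 mg/kg, with an expected range from 12 mg/kg to 40 mg/kg.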

Compound 4, dose for half-maximal effect: 62 mg/kg
Beside the measured number, compound 4's estimate is 2.8-fold (0.45 log units) below it, outside the stated range (above it).
By their numbers in this assay, from the lowest: compounds 2, 3 and 1 (each within the scatter of the next); then compound 4.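

Within this assay the halogen is not interchangeable: bromo in place of chloro on the aromatic carbon brings a 2.6-fold higher number from compound 3 to compound 4 (0.41 log units; beyond the scatter) in the amide series. With bromo held constant, the group on the carbonyl carbon matters too, since amino brings a 2.3-fold higher number from compound 1 to compound 4 (0.36 log units; beyond the scatter) in place of hydroxy and a 4.4-fold higher number from compound 2 to compound 4 (0.65 log units; beyond the scatter) in place of methoxy. No evidence at hand explains these steps.

The compounds shown leave open whether fluoro or a methyl group on that aromatic carbon would track chloro or bromo. They also leave open whether the halogen exchange would act the same way in the carboxylic acid and the methyl ester.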